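The source may report more compounds than this note shows. Statements on the series, on what has been measured and on what is new or still open speak of the compounds shown alone.

Compound 2 `CCOC(=O)c1cn(Cc2nnc(-c3cc(S(N)(=O)=O)c(SCc4ccccc4)cc3Cl)o2)nn1` holds the lower of the two half-lives measured so far: in an ADME assay on microsomes from liver (Homo sapiens) for metabolic stability, read by LC-MS, using NADPH, tested at 5 uM (a higher number here means that the compound lasts longer, a lower number that the compound disappears faster), compound 2 gives 0.085 h, whereas compound 1 `NS(=O)(=O)c1cc(-c2nnc(CCl)o2)c(Cl)cc1SCc1ccccc1` gives 0.235 h. Within the data shown here, the only measured step, a 2.8-fold lower number from compound 1 to compound 2 (0.44 log units; beyond the scatter), concerns a different change and does not touch the ester. Compound 3 `NC(=O)c1cn(Cc2nnc(-c3cc(S(N)(=O)=O)c(SCc4ccccc4)cc3Cl)o2)nn1` differs from compound 2 by amino in place of ethoxy on a carbonyl carbon. Among the measured compounds shown here, no measured step bears on this change, so no step beyond the scatter is expected for compound 3 in this assay. The half-life of compound 3 is estimated at 0.13 h, within 0.05 h to 0.35 h, a step of a 1.5-fold higher number from compound 2 to compound 3 (0.18 log units; within the scatter).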

Compound 3, half-life: 0.435 h
Beside the measured number, compound 3's estimate is 3.3-fold (0.52 log units) below it, and the stated range ends below it.
By their numbers in this assay, from the lowest: compound 2; then compounds 1 and 3 (each within the scatter of the next).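

In this assay, the group on the carbonyl carbon proves to matter: amino in place of ethoxy gives a 5.1-fold higher number from compound 2 to compound 3 (0.71 log units; beyond the scatter), so the ester is the shorter-lived of this pair. Set against the chloro group on the saturated chain carbon, the 4-carbamoyl-1H-1,2,3-triazol-1-yl group gives a 1.9-fold higher number from compound 1 to compound 3 (0.27 log units; within the scatter), which leaves no separation between those two compounds. Nothing available here accounts for the difference between ethoxy and amino. Still open, going by these compounds, is how a carboxylic acid, or a methylamino group, on this carbonyl carbon would compare with amino and ethoxy.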